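A few compounds are considered here, and "the series" means these few. Any claim that something is new, unique, unknown or untested is made for them only; others in the source may bear on it.

Of the compounds shown here, two have numbers so far. In an ADME assay on microsomes from liver (Rattus norvegicus) for metabolic stability, with a stated time of 10 min, tested at 0.5 uM (a higher number here means that more of the compound is left, a lower number that less of the compound is left), compound 1 (`CC(C)COc1ncc(-c2cn(C)c3cc(C(=O)NS(C)(=O)=O)ccc23)cc1Cl`) gives 66% and compound 2 (`CC(C)COc1ncc(-c2cn(C)c3cc(C(=O)NS(=O)(=O)C4CC4)c(F)cc23)cc1Cl`) gives 37% as the lower of the two numbers. This gap lies beyond the usual scatter, which leaves compound 2 at the low end of the measured range. The two compounds differ in more than one place, so the gap cannot be assigned to any single structural feature.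

The change from compound 2 to compound 3 (`CC(C)COc1ccc(-c2cn(C)c3cc(C(=O)NS(=O)(=O)C4CC4)c(F)cc23)cn1`) is a single one (hydrogen in place of chloro on an aromatic carbon), with hydrogen in place of chloro on an aromatic carbon. For the measured compounds named here, both measured compounds carry the chloro, and no measured pair shows this change alone, so the data give no direct size for it. The expected step of a number 7 percentage points higher from compound 2 to compound 3 (within the scatter) is therefore small and upward, and it is expected to stay within the scatter, although the uncertainty is wide. Compound 3 is estimated at 44% in this assay with an expected range from 24% to 66% of compound left.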

Compound 3, percent of the compound remaining: 78%
Compound 3: middle estimate off by 34 percentage points, on the low side; the whole stated range lies below it.
By their numbers in this assay, from the lowest: compound 2; then compound 1; then compound 3.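

In this assay, hydrogen in place of chloro on an aromatic carbon, ortho to an isobutoxy group and two atoms from the ring nitrogen, gives a number 41 percentage points higher from compound 2 to compound 3 (beyond the scatter). For the compounds shown here, this is the first pair that differs in one place, so the size of a change at this position can now be read directly: one atom exchanged on an otherwise unchanged structure moves the percent of compound remaining well past the usual scatter, and the chloro-to-hydrogen exchange is the only difference to which that shift can be assigned. Going by these compounds alone, nothing measured so far addresses why the number moves this far with this exchange.

Going by these compounds, the reading rests on a single pair, so whether the same exchange gives a step of similar size on the core of compound 1 remains open. Also open, on these data alone, is where other substituents on this carbon, such as a methyl group, a nitrile or a methoxy group, would fall relative to the hydrogen and the chloro, and whether a shorter ether in place of the isobutoxy group changes the picture.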